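The source may hold more compounds than are shown below. What is called first, only, known or untested is meant among the compounds shown, and "the series" means these compounds.

Measured so far: compound 1 `COc1ccc(NC(=O)Nc2cccc(CNc3ncnc4ccccc34)c2)cc1` with > 50000 nM; compound 2 `CC(C)(C)c1ccc(NC(=O)Nc2cccc(CNc3ncnc4ccccc34)c2)cc1` with 17000 nM; compound 3 `COc1ccc(NC(=O)Nc2cccc(CNc3ncnc4cc(OC)c(OC)cc34)c2)cc1` with > 50000 nM.

In a functional assay on HepG2 cells (Homo sapiens) for antiproliferative activity, read by MTT assay (a higher number here means a weaker inhibitor, a lower number a stronger inhibitor), compound 1 gives > 50000 nM, which is a limit of the assay rather than a number. Compound 2 gives 17000 nM in this assay, so the change tert-butyl in place of methoxy on an aromatic carbon produced an at least 2.9-fold lower number from compound 1 to compound 2 (0.46 log units; beyond the scatter); note (the limit of > 50000 nM in this assay, at which 2 of the 3 values shown sit). Compound 3 gives > 50000 nM in this assay, again only a limit. The difference between the cores of compound 1 and compound 3 is not broken down here.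

Compound 4 `COc1cc2ncnc(NCc3cccc(NC(=O)Nc4ccc(C(C)(C)C)cc4)c3)c2cc1OC` is not yet measured. It differs from compound 3 by tert-butyl in place of methoxy on an aromatic carbon, the same change that separates compound 1 from compound 2. Resting on an at least 2.9-fold lower number from compound 1 to compound 2 (0.46 log units; beyond the scatter), compound 4 is expected to show an at least 2.0-fold lower number from compound 3 to compound 4 (0.30 log units; that floor lies within the scatter) in this assay. The estimate for compound 4 in this assay is 25000 nM, between 8000 nM and 60000 nM.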

Compound 4, half-maximal inhibitory concentration: 6850 nM
Beside the measured number, compound 4's estimate is 3.6-fold (0.56 log units) above it; the measured number lies below the stated range.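

In this assay, tert-butyl in place of methoxy on an aromatic carbon again gives a lower number, an at least 7.2-fold lower number from compound 3 to compound 4 (0.86 log units; beyond the scatter), so the direction of the change seen on the core of compound 1 carries over to the second core. Whether the size of the step carries over as well stays undecided: the same change on two cores in this assay, an at least 2.9-fold lower number (0.46 log units; beyond the scatter) from compound 1 to compound 2 and an at least 7.2-fold lower number (0.86 log units; beyond the scatter) from compound 3 to compound 4; the limit leaves it open whether they differ. Both steps are floors rather than exact sizes, and the two cores therefore cannot be ranked by how much they gain from the change: the limit of > 50000 nM in this assay, at which 2 of the 4 values shown sit.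

The compounds shown leave open how an amine, a carboxylic acid or a longer alkyl chain would behave in place of the tert-butyl. They also leave open whether the same change would lower the number on any further core.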